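The compounds below may be only part of what the source reports. "The series", "measured", "known", "first", "only" and "open" are said of these compounds alone.

Working notes on the series. In a functional assay on Shh Light II cells (Mus musculus) for inhibition, read by a luciferase reporter (a higher number here means a weaker inhibitor, a lower number a stronger inhibitor), compound 1 `O=C(NCC1CCC1)N1CCC(c2nc(-c3ccc4ccccc4n3)no2)CC1` gives 410 nM and compound 2 `COc1ccccc1NC(=O)N1CCC(c2nc(-c3ccc4ccccc4n3)no2)CC1` gives 410 nM, so compound 2 stands level with compound 1 and has no other measured neighbour. Compound 3 `Cc1noc(C)c1NC(=O)N1CCC(c2nc(-c3ccc4ccccc4n3)no2)CC1` keeps the shared core and alters the same position: 3,5-dimethyl-1,2-oxazol-4-yl in place of 2-methoxyphenyl on an amide-type nitrogen. In words, 3,5-dimethyl-1,2-oxazol-4-yl stands in place of 2-methoxyphenyl on an amide-type nitrogen.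

For the measured compounds named here, only one measured step bears on this position: no change at the digits printed from compound 1 to compound 2 (within the scatter). That step exchanged one substituent on the amide-type nitrogen for a quite different one, and the value stayed within the scatter. It is a single comparison, and no group with a five-membered aromatic ring has yet been measured at this position, so the evidence is thin. On this basis, no step beyond the scatter is expected in this assay, and neither direction is favoured. The estimated step runs no change at the digits printed from compound 2 to compound 3 (within the scatter). Compound 3 is estimated at 410 nM, with an expected range of 150 nM to 1100 nM.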

Compound 3, half-maximal inhibitory concentration: 3000 nM
For compound 3 the middle estimate is 7.3-fold (0.86 log units) below the measured one; the measured number lies above the stated range.
By their numbers in this assay, from the lowest: compounds 1 and 2 (each within the scatter of the next); then compound 3.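

This position does not tolerate every substituent equally. In this assay the exchange of 2-methoxyphenyl for 3,5-dimethyl-1,2-oxazol-4-yl gives a 7.3-fold higher number from compound 2 to compound 3 (0.86 log units; beyond the scatter) and, measured against cyclobutylmethyl, the same group gives a 7.3-fold higher number from compound 1 to compound 3 (0.86 log units; beyond the scatter) on the same amide-type nitrogen. The earlier level shared by two quite different substituents therefore does not extend to all groups here, and the five-membered aromatic ring with 2 hetero atoms is the weakest inhibitor of the three, while nothing at hand accounts for the rise.

The compounds shown leave open whether the higher number goes with the five-membered ring, with its hetero atoms or with its two methyl groups, and a plain phenyl, a 2-methylphenyl or an unsubstituted 1,2-oxazol-4-yl on this nitrogen would begin to separate these. Going by these compounds, it also remains open whether other five-membered aromatic rings, such as a thiophene or a pyrazole, would stay level with the first two compounds or follow compound 3 towards weaker inhibition.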